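This account rests on a few compounds, and the source may have more. Where it says the series, first, only, none or still open, it means among the compounds named here.

In a functional assay on MCF7 cells (Homo sapiens) for antiproliferative activity, read by MTT assay, with a stated time of 48 h (a higher number here means a weaker inhibitor, a lower number a stronger inhibitor), compound 1 `COc1ccc(/C=C/C(=O)Nc2nnc(-c3ccc(C)cc3)s2)cc1` gives 0.35 ug/mL, compound 2 `COc1ccc(/C=C/C(=O)Nc2nnc(-c3ccc(Cl)cc3)s2)cc1` gives 0.91 ug/mL and compound 3 `COc1ccc(-c2nnc(NC(=O)/C=C/c3ccc(C(F)(F)F)cc3)s2)cc1` gives 0.79 ug/mL. Compound 3 thus lies within the scatter of compound 2, while compound 1 has a lower number than compound 3, beyond the scatter. Compound 4 `COc1ccc(/C=C/C(=O)Nc2nnc(-c3ccc(OC)cc3)s2)cc1` carries methoxy in place of trifluoromethyl on an aromatic carbon, para to a large group: methoxy in place of trifluoromethyl on an aromatic carbon. Among the compounds with values here, no measured step makes this exchange. The nearest guide is a different exchange on an aromatic carbon, a 2.6-fold higher number from compound 1 to compound 2 (0.41 log units; beyond the scatter), so at most a modest step is expected in this assay, with no clear direction. The expected change is a 1.3-fold lower number from compound 3 to compound 4 (0.12 log units; within the scatter), which stays within the scatter. The estimate for compound 4 is 0.6 ug/mL, with an expected range of 0.25 ug/mL to 1.4 ug/mL.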

Compound 4, half-maximal inhibitory concentration: 0.28 ug/mL
Compound 4: the middle estimate sits 2.1-fold (0.33 log units) above what was measured; the range from low to high includes it.
By their numbers in this assay, from the lowest: compounds 4 and 1 (each within the scatter of the next); then compounds 3 and 2 (each within the scatter of the next).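

In this assay methoxy on an aromatic carbon, para to a large group, gives a lower number than trifluoromethyl (a 2.8-fold lower number from compound 3 to compound 4 (0.45 log units; beyond the scatter)) and than chloro (a 3.3-fold lower number from compound 2 to compound 4 (0.51 log units; beyond the scatter)). Against methyl it brings no change that stands out from the scatter (a 1.3-fold lower number from compound 1 to compound 4 (0.10 log units; within the scatter)), so methoxy and methyl cannot be told apart here. No evidence is available that accounts for these steps. On these data alone, whether an ethoxy group, a hydroxyl or an amine at this carbon would match methoxy remains open. So does whether a longer chain would hold the low number.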